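A few compounds are considered here, and "the series" means these few. Any claim that something is new, unique, unknown or untested is made for them only; others in the source may bear on it.

A small set of compounds built on one shared core was tested in a functional assay on Hep2C cells (Homo sapiens) for antiproliferative activity, read by MTT assay, with a stated time of 24 h; a lower number here means a stronger inhibitor, a higher number a weaker inhibitor. Compound 1, `COc1ccc2nc(-c3ccccc3)cc(-c3ccccc3)c2c1`, is one of them; in this assay compound 1 gives 496000 nM. Compound 2, `Clc1ccc(-c2cc(-c3ccccc3)c3cc(Br)ccc3n2)cc1`, is another; in this assay compound 2 gives 269000 nM. These two numbers lie within the usual scatter of each other, so neither compound can be called the stronger inhibitor on this evidence. Compound 3, `Oc1ccc2c(-c3ccccc3)cc(-c3ccccc3)nc2c1`, was also part of the set, but for compound 3 this assay reports "not determined" (no result reported), so it adds no number to compare.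

Compound 4, `Oc1ccc(-c2cc(-c3ccccc3)c3cc(Br)ccc3n2)cc1`, is compound 2 with a single change: hydroxy in place of chloro on an aromatic carbon. Among the compounds with values here, no pair of measured compounds differs in exactly this way, so there is no measured step to lean on. What is known is that compound 2 gives 269000 nM in this assay and compound 1 gives 496000 nM, both large numbers close to each other. With nothing pointing either way, the step is expected to be a 1.1-fold higher number from compound 2 to compound 4 (0.05 log units; within the scatter), none beyond the scatter. Compound 4 is therefore estimated to give 300000 nM in this assay, with a plausible range from 120000 nM to 750000 nM.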

Compound 4, half-maximal inhibitory concentration: 105000 nM
Beside the measured number, compound 4's estimate is 2.9-fold (0.46 log units) above it; measured number outside the range, below it.
By their numbers in this assay, from the lowest: compound 4; then compounds 2 and 1 (each within the scatter of the next).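

In this assay, replacing chloro with hydroxy on the aromatic carbon para to a large group gives a 2.6-fold lower number from compound 2 to compound 4 (0.41 log units; beyond the scatter). Within the data shown here, this is the first step in the set that compares two compounds differing in one place, so it shows that this position is not indifferent to the group it carries: going from 4-chlorophenyl to 4-hydroxyphenyl moves the number beyond the usual scatter, although compound 4 still gives a large value of 105000 nM. The compounds shown offer no independent measurement that could say why the number moves, so this single step records the change without explaining it.

As far as these compounds go, it remains open whether the lower number is particular to hydroxy or would also appear with another group at this place, such as an amine, a carboxylic acid or a methoxy group. A single step also cannot show whether the same exchange would give a similar step on a core without the bromo group, or on the other phenyl ring of the shared core.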